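This account rests on a few compounds, and the source may have more. Where it says the series, first, only, none or still open, it means among the compounds named here.

Working notes on the series.

Compound 1, `CN1CCN(c2nc(-c3ccc(Cl)c(Cl)c3)nc3c2ncn3C)CC1`, gives 28.3% in an assay on cells for displacement of a labelled ligand from adenosine receptor A2b (Homo sapiens), read by scintillation counting and radioligand binding, with a stated time of 30 min, tested at 10 uM; a lower number here means less inhibition, a higher number more inhibition at the concentration tested (going by the name of the read-out). Compound 3, `CN1CCN(c2nc(-c3cccc(Cl)c3)nc3c2ncn3C)CC1`, differs from compound 1 by hydrogen in place of chloro on an aromatic carbon. In this assay compound 3 gives 19.2%; the step of a number 9.1 percentage points lower from compound 1 to compound 3 (within the scatter). Compound 2, `Clc1ccc(Cl)c(-c2nc(N3CCCCC3)c3nc[nH]c3n2)c1`, carries a different core; the difference between the two cores is not broken down here. In this assay compound 2 gives 12.1%, the lowest of the three numbers, within the scatter of compound 3 and beyond it only against compound 1.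

Compound 4, `Clc1cccc(-c2nc(N3CCCCC3)c3nc[nH]c3n2)c1`, is not yet measured. It differs from compound 2 by hydrogen in place of chloro on an aromatic carbon. This is the same kind of change as that from compound 1 to compound 3, but the surroundings of the place differ: in compound 1 the leaving chloro sits ortho to a chloro group and para to a large group, in compound 2 ortho to a large group and para to a chloro group.

Going by the values given here, the step from compound 2 to compound 4 is expected to be a number 3.1 percentage points lower from compound 2 to compound 4 (within the scatter), resting on the single earlier step of a number 9.1 percentage points lower from compound 1 to compound 3 (within the scatter), which lay within the scatter, so little movement is expected. Compound 4 is estimated at 9% in this assay, with a range from -2% to 22%.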

Compound 4, a percentage reported as inhibition, at one concentration (the size of the read-out at that concentration, not a potency): > 80%
Compound 4: a limit, no number; the forecaster's own chance of this, stated with the estimate: 0%; at least 71 percentage points between middle value and limit.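

In this assay compound 4 gives > 80%, which is a limit of the assay and not a number. Hydrogen in place of chloro on an aromatic carbon gives a number at least 67.9 percentage points higher from compound 2 to compound 4 (beyond the scatter), so the change does not carry over unchanged from one core to the other: the same change on two cores in this assay, a number 9.1 percentage points lower (within the scatter) from compound 1 to compound 3 and a number at least 67.9 percentage points higher (beyond the scatter) from compound 2 to compound 4, at least 77 percentage points apart, beyond the scatter of two such steps

This does not show which feature of the two cores, or of the surroundings of the leaving chloro, sets the two steps apart, and with a single pair on each core it gives no rule for any further core.

Left open is whether a fluoro group, a methoxy group or a nitrile in place of the chloro that leaves compound 2 would give a similar read-out to hydrogen. Also open, from the compounds shown here alone, is how the read-out responds on the core of compound 4 when an open-chain amine replaces the ring amine there.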